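Trading a dichlorophenyl for a methylphenyl on the benzyl ether

A few compounds are considered here, and "the series" means these few. Any claim that something is new, unique, unknown or untested is made for them only; others in the source may bear on it.

Measured so far:
Compound 1 `Cc1cccc(COc2ccc(/C=C/C(/C=C/c3ccccn3)=N/Oc3ncnc4cccc(C)c34)cc2)c1`: 97%
Compound 2 `Fc1ccccc1COc1ccc(/C=C/C(/C=C/c2ccccn2)=N/Oc2ncnc3cc(Cl)ccc23)cc1`: 91.2%
Compound 3 `Clc1ccc(COc2ccc(/C=C/C(/C=C/c3ccccn3)=N/Oc3ncnc4cc(Cl)ccc34)cc2)c(Cl)c1`: 23.6%

In a functional assay on SMMC-7721 cells (Homo sapiens) for inhibition, read by MTT assay, with a stated time of 72 h, tested at 10 uM (on this read-out lower numbers stand for a weaker effect and higher numbers for a stronger effect at the one concentration tested), compound 3 stands lowest of the three numbers, with compound 2 nearest and compound 1 furthest away, both well above it. Going by the values given here, the one measured step that bears on the change at hand is a number 67.6 percentage points lower from compound 2 to compound 3 (beyond the scatter), a large drop when the benzyl group carrying a single fluorine gave way to one carrying two chlorines on the same chloro-bearing core.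

Compound 4 `Cc1cccc(COc2ccc(/C=C/C(/C=C/c3ccccn3)=N/Oc3ncnc4cc(Cl)ccc34)cc2)c1` reverses that kind of change: 3-methylphenyl in place of 2,4-dichlorophenyl on a saturated chain carbon bound to an oxygen on an aromatic ring. Its 3-methylbenzyl group is the very one found in compound 1, which, on a core differing only in its methyl in place of chlorine, gave 97% in this assay. Because a number 67.6 percentage points lower from compound 2 to compound 3 (beyond the scatter) shows the 2,4-dichlorophenyl to be the weak member of this small set, replacing it is expected to restore a strong effect, a step of a number 66.4 percentage points higher from compound 3 to compound 4 (beyond the scatter) upward beyond the scatter. Compound 4 is therefore estimated at 90%, within 70% to 99%.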

Compound 4, a percentage reported as inhibition, at one concentration (the size of the read-out at that concentration, not a potency): 95.6%
Compound 4: middle estimate off by 5.6 percentage points, on the low side, within the range that was stated.
By their numbers in this assay, from the lowest: compound 3; then compounds 2, 4 and 1 (each within the scatter of the next).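

In this assay, a second group on the same chloro-bearing core now undoes the loss seen with the 2,4-dichlorophenyl, with a number 72 percentage points higher from compound 3 to compound 4 (beyond the scatter), and the 3-methylphenyl and 2-fluorophenyl cannot be told apart, with a number 4.4 percentage points higher from compound 2 to compound 4 (within the scatter), so the low reading of compound 3 does not depend on one particular replacement. With the 3-methylphenyl held fixed, changing the core also leaves no measurable difference, with a number 1.4 percentage points lower from compound 1 to compound 4 (within the scatter) and 7-chloroquinazolin-4-yl in place of 5-methylquinazolin-4-yl on an oxygen. Nothing available here explains why the 2,4-dichlorophenyl reads so differently from the other two groups.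

The compounds shown leave open which of the two chlorines goes with the low reading, and whether a high reading survives with an amine or a carboxylic acid on this ring. These readings also come from one concentration, so they do not rank potency.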